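The source may report more compounds than this note shows. Statements on the series, on what has been measured and on what is new or still open speak of the compounds shown alone.

Of the compounds shown here, three with a shared core have been measured in an assay on CHO cells for displacement of a labelled ligand from 5-hydroxytryptamine receptor 1B (Homo sapiens); a lower number here means a stronger inhibitor, a higher number a weaker inhibitor. Compound 1, `O[C@H]1Cc2ccccc2C1NC1CCN(CCCc2c[nH]c3ccc(-n4cnnc4)cc23)CC1`, gives 300 nM. Compound 2, `CC(C)=CCN(C)C1CCN(CCCc2c[nH]c3ccc(-n4cnnc4)cc23)CC1`, gives 41 nM. Compound 3, `c1cncc(CNC2CCN(CCCc3c[nH]c4ccc(-n5cnnc5)cc34)CC2)c1`, gives 140 nM. Among these three numbers compound 3 stands second highest: the step of a 2.1-fold lower number from compound 1 to compound 3 (0.33 log units; beyond the scatter) is modest, and the step of a 3.4-fold higher number from compound 2 to compound 3 (0.53 log units; beyond the scatter) is also modest, so compound 3 sits between the other two.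

Compound 4, `c1ccc2c(c1)CCC2NCC1CCN(CCCc2c[nH]c3ccc(-n4cnnc4)cc23)CC1`, has not yet been measured. It differs from compound 3 in one place: ((2,3-dihydro-1H-inden-1-yl)amino)methyl in place of ((pyridin-3-yl)methyl)amino on a saturated ring carbon. The step that bears most on this change is a 2.1-fold lower number from compound 1 to compound 3 (0.33 log units; beyond the scatter), since compound 1 carries a related 2-hydroxy-2,3-dihydro-1H-inden-1-yl group directly on the amine nitrogen. Within the data shown here, in compound 4 the ring lacks the hydroxyl and is joined through an extra methylene, for which no measured pair exists. Going back toward a group like that of compound 1 would be expected to raise the number modestly, roughly reversing a 2.1-fold lower number from compound 1 to compound 3 (0.33 log units; beyond the scatter), though the change itself is not directly covered.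

Compound 4 is therefore expected to show 220 nM, within a range from 70 nM to 700 nM, meaning an estimated step of a 1.6-fold higher number from compound 3 to compound 4 (0.20 log units; within the scatter).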

Compound 4, half-maximal inhibitory concentration: 25 nM
Beside the measured number, compound 4's estimate is 8.8-fold (0.94 log units) above it; the measured number lies below the stated range.
By their numbers in this assay, from the lowest: compounds 4 and 2 (each within the scatter of the next); then compound 3; then compound 1.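

In this assay, moving to the ((2,3-dihydro-1H-inden-1-yl)amino)methyl group on this saturated ring carbon gives a 5.6-fold lower number from compound 3 to compound 4 (0.75 log units; beyond the scatter) and a 12-fold lower number from compound 1 to compound 4 (1.08 log units; beyond the scatter), the largest step seen so far in this set. Among these compounds, the only earlier compound with a 2,3-dihydro-1H-inden-1-yl unit, compound 1, has the highest number of the set, so compound 4 shows that a group of this family at this position is compatible with a low number, and a 1.6-fold lower number from compound 2 to compound 4 (0.21 log units; within the scatter) places it level with the methyl(3-methylbut-2-en-1-yl)amino group of compound 2. Nothing measured on these compounds explains why the number moves this way.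

Compound 4 differs from compound 1 both in lacking the hydroxyl and in having an extra methylene, so the compounds shown cannot tell how much of that step belongs to each change. A plain (2,3-dihydro-1H-inden-1-yl)amino group on the same ring carbon would separate the two, and a ((pyridin-3-yl)methylamino)methyl group would show whether the extra methylene alone matters with the pyridine ring.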